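Two pentyl triazoles and the step between their esters

The compounds below may be only part of what the source reports. "The series", "measured", "known", "first", "only" and "open" are said of these compounds alone.

Measured so far:
compound 1, `CCCCCc1cn(C/C=C(\C)CCC=C(C)C)nn1`, 5.45 
compound 2, `COC(=O)c1cn(C/C=C(\C)CCC=C(C)C)nn1`, 3.2 
compound 3, `COC(=O)c1cn(C/C=C(\C)CC/C=C(\C)CCC=C(C)C)nn1`, 5.25 

Three compounds have been run in a physicochemical assay for lipophilicity, measured as octanol-water partition; a higher number here means a more lipophilic compound, a lower number a more polar compound. Compound 2 gives 3.2, the lowest of the three numbers. Compound 1 differs from compound 2 in one place, (pentyl in place of methoxycarbonyl on an aromatic carbon), and the step in this assay is a number 2.25 log units higher from compound 2 to compound 1 (beyond the scatter). Compound 3 differs from compound 2 at another place, (3-methylbut-2-en-1-yl in place of hydrogen on a saturated chain carbon bound to a double-bonded chain carbon), and the step there is a number 2.05 log units higher from compound 2 to compound 3 (beyond the scatter). Compound 1 and compound 3 lie within the scatter of each other, so no order between them is claimed.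

Compound 4, `CCCCCc1cn(C/C=C(\C)CC/C=C(\C)CCC=C(C)C)nn1`, has not yet been measured. It differs from compound 3 in one place, (pentyl in place of methoxycarbonyl on an aromatic carbon). This is the same change that turns compound 2 into compound 1, at the same place on the ring, and it occurs twice among the four compounds. The two cores differ as 3-methylbut-2-en-1-yl in place of hydrogen on a saturated chain carbon bound to a double-bonded chain carbon describes.

Among the compounds with values here, with only one earlier instance of this change, the expectation for compound 4 rests on that single step, a number 2.25 log units higher from compound 2 to compound 1 (beyond the scatter), carried over to compound 3. Compound 4 is therefore expected to show a step of a number 2.25 log units higher from compound 3 to compound 4 (beyond the scatter) in this assay. Compound 4 is estimated at 7.5, with a range from 7 to 8.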

Compound 4, partition coefficient: 7.5
Beside the measured number, compound 4's estimate shows no gap at the digits printed; the measured number falls inside the stated range.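

In this assay the change from methoxycarbonyl to pentyl on the aromatic carbon gives a number 2.25 log units higher from compound 3 to compound 4 (beyond the scatter) and that step matches in size a number 2.25 log units higher from compound 2 to compound 1 (beyond the scatter) so the change carried over from the core of compound 2 to the core of compound 3 with no difference at the digits printed. Read the other way, adding 3-methylbut-2-en-1-yl gives a number 2.05 log units higher from compound 1 to compound 4 (beyond the scatter) with pentyl on the ring and a number 2.05 log units higher from compound 2 to compound 3 (beyond the scatter) with methoxycarbonyl on the ring, so the two changes add up across these four compounds and none goes against that, but this rests on a single pair of cores and shows nothing about any other core or any other group. Nothing measured here speaks to why the steps agree.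

The compounds shown leave open whether the same match would hold if an amine or a carboxylic acid stood on that aromatic carbon in place of pentyl or methoxycarbonyl. They also leave open whether this assay would show the same match for a chain longer than pentyl at that place, or for a further 3-methylbut-2-en-1-yl unit on the other chain.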